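Adding a methyl to the core of compound 2

This account rests on a few compounds, and the source may have more. Where it says the series, first, only, none or still open, it means among the compounds named here.

Measured so far in an ADME assay on microsomes from liver (Rattus norvegicus) for metabolic stability, read by LC-MS, using NADPH, with a stated time of 10 min, tested at 0.5 uM (a higher number here means that more of the compound is left, a lower number that less of the compound is left), for three compounds
Compound 1 `COC(=O)Nc1cc(-c2cnc(OC[C@@](C)(N)CC(C)C)c(Cl)c2)ccn1` gives 73%
Compound 2 `COC(=O)Nc1cc(-c2ccc(OC[C@@](C)(N)CC(C)C)nc2)ccn1` gives 96%
Compound 3 `COC(=O)Nc1cc(-c2cnc(OC[C@@](C)(N)CC(C)C)c(C#N)c2)ccn1` gives 80%

Compound 2 stands highest of the three, and both other compounds lie beyond the scatter below it. Compound 4 `COC(=O)Nc1cc(-c2cnc(OC[C@@](C)(N)CC(C)C)cc2C)ccn1` carries one change from compound 2, methyl in place of hydrogen on an aromatic carbon, counted out as methyl in place of hydrogen on an aromatic carbon in full. Among the compounds with values here, two measured steps bear on this change, and both are modest. They are a number 23 percentage points higher from compound 1 to compound 2 (beyond the scatter) in one case and a number 16 percentage points lower from compound 2 to compound 3 (beyond the scatter) in the other. In both, the compound with hydrogen gives the higher number. Neither step introduces a methyl or alters this same aromatic carbon, so they are only a loose guide. A modest drop is therefore expected in this assay for this change. The estimate amounts to a number 12 percentage points lower from compound 2 to compound 4 (beyond the scatter) as an expected step. For compound 4 the expected value is 84% with an estimated range from 66% to 97% in this read-out.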

Compound 4, percent of the compound remaining: 87%
For compound 4 the middle estimate is 3 percentage points below the measured one; low and high end bracket the measured number.
By their numbers in this assay, from the lowest: compounds 1, 3, 4 and 2 (each within the scatter of the next, the first and the last beyond it).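

At this aromatic carbon, ortho to a large group and opposite the ring nitrogen, this assay now gives a direct reading for methyl in place of hydrogen: a number 9 percentage points lower from compound 2 to compound 4 (within the scatter). Compound 2 and compound 4 therefore cannot be told apart in this read-out, so this position accepts one added carbon without a step beyond the scatter. The chloro and cyano changes, made at a different aromatic carbon, did give steps beyond the scatter against compound 2, so those steps do not carry over to this position. No measured finding accounts for the result. On these data alone, whether an amine or a longer chain such as propyl on this carbon would also stay within the scatter of compound 2 remains open. So does the effect of this methyl alongside the chloro of compound 1 or the cyano of compound 3.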